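A few compounds are considered here, and "the series" means these few. Any claim that something is new, unique, unknown or untested is made for them only; others in the source may bear on it.

Measured in a physicochemical assay for solubility, in phosphate buffer, measured as kinetic solubility, at pH 7.4; on this read-out higher numbers stand for higher solubility and lower numbers for lower solubility:
Compound 1 `Cc1oc(-c2c(Br)cccc2Br)nc1CN1CCC(C(=O)NCCCN2C[C@H](C)C[C@H](C)C2)CC1`: 62.4 ug/mL
Compound 2 `COc1cccc(Br)c1-c1nc(CN2CCC(C(=O)NCCCN3C[C@H](C)C[C@H](C)C3)CC2)c(C)o1`: > 83 ug/mL (a limit of the assay)

Compound 2 has no exact number, since its reading is a limit of the assay, > 83 ug/mL. Compound 3 `CCc1ccccc1-c1nc(CN2CCC(C(=O)NCCCN3C[C@H](C)C[C@H](C)C3)CC2)c(C)o1` carries 2-ethylphenyl in place of 2-bromo-6-methoxyphenyl on an aromatic carbon. Among the compounds with values here, only one measured step bears on this change, and it covers only part of it: an at least 1.3-fold higher number from compound 1 to compound 2 (0.12 log units; that floor lies within the scatter), with methoxy in place of bromo on an aromatic carbon. Within the data shown here, no measured step shows the effect of the ethyl group. Resting on an at least 1.3-fold higher number from compound 1 to compound 2 (0.12 log units; that floor lies within the scatter), no change beyond the scatter is expected in this assay, and no direction can be favoured with confidence. The expected size is an at least 1.2-fold lower number from compound 2 to compound 3 (0.10 log units; that floor lies within the scatter). Compound 3 is estimated at 65 ug/mL, with an expected range from 35 ug/mL to 100 ug/mL.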

Compound 3, solubility: 55.9 ug/mL
The estimate for compound 3 lay 1.2-fold (0.07 log units) above the measured number; the measured number falls inside the stated range.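

In this assay, the change to 2-ethylphenyl in place of 2,6-dibromophenyl gives a 1.1-fold lower number from compound 1 to compound 3 (0.05 log units; within the scatter), so this aromatic carbon of the five-membered ring now has two quite different aryl groups that read alike within the scatter. The other new step is an at least 1.4-fold lower number from compound 2 to compound 3 (0.17 log units; that floor lies within the scatter). This is only a floor, and the true size of the step cannot be fixed because compound 2 carries a limit of the assay and not a number: the limit of > 83 ug/mL in this assay, at which 1 of the 3 values shown sits.

From the compounds shown here alone, whether 2-bromo-6-methoxyphenyl truly stands apart from the other two aryl groups therefore stays open. Also open, going by these compounds, is how an aryl group bearing an amine or a carboxylic acid in place of the ethyl group would read in this assay.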